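Extending the Chain on a Weak Inhibitor

This account rests on a few compounds, and the source may have more. Where it says the series, first, only, none or still open, it means among the compounds named here.

Compound 3 `CCc1cc2ccccc2nc1-c1cc(-c2ccc(C(F)(F)F)cc2)no1` stands only at a limit in a functional assay on COLO 205 cells (Homo sapiens) for inhibition, read by MTT assay, with a stated time of 24 h (on this read-out lower numbers stand for stronger inhibition and higher numbers for weaker inhibition), where its reading is > 100000 nM. Compound 1 `CCCc1cc2ccccc2nc1-c1cc(-c2ccc(F)cc2)no1` gives 50300 nM in this assay. Compound 2 `CCCc1cc2ccccc2nc1-c1cc(-c2ccc(C)cc2)no1` also sits at a limit, with a reading of > 100000 nM. Within the data shown here, the single measured step, an at least 1.9-fold higher number from compound 1 to compound 2 (0.29 log units; that floor lies within the scatter), concerns the substituent on the aromatic ring and not the chain, and two of the three readings rest at the limit of > 100000 nM in this assay, at which 2 of the 3 values shown sit. Compound 4 `CCCc1cc2ccccc2nc1-c1cc(-c2ccc(C(F)(F)F)cc2)no1` differs from compound 3 by methyl in place of hydrogen on a saturated chain carbon, two bonds along the chain from an aromatic carbon. Among the measured compounds shown here, no measured pair shows this chain change, so no step beyond the scatter in this assay is expected. Compound 4 is expected to give about 100000 nM, between 40000 nM and 300000 nM, most likely reported again as a limit. The expected step of a number no higher from compound 3 to compound 4 (the limit leaves the size open) is accordingly essentially none.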

Compound 4, half-maximal inhibitory concentration: 42200 nM
The estimate for compound 4 lay 2.4-fold (0.37 log units) above the measured number; low and high end bracket the measured number.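

In this assay, the change from ethyl to propyl at this chain position gives a readable shift, with an at least 2.3-fold lower number from compound 3 to compound 4 (0.37 log units; beyond the scatter) on the way. With the propyl chain held fixed, the aromatic substituent also counts: trifluoromethyl in place of methyl gives an at least 2.3-fold lower number from compound 2 to compound 4 (0.37 log units; beyond the scatter) as its result, while trifluoromethyl in place of fluoro gives a 1.2-fold lower number from compound 1 to compound 4 (0.08 log units; within the scatter) and so cannot be told apart. The first two steps start from a limit and not from a number, so their true sizes stay open: the limit of > 100000 nM in this assay, at which 2 of the 4 values shown sit.

On these data alone, whether a longer chain such as butyl would continue the change from ethyl to propyl remains open. So does the effect of an amine on the aromatic ring in place of trifluoromethyl.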